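A Chloro Swap Across Two Related Cores

The source may hold more compounds than are shown below. What is called first, only, known or untested is meant among the compounds shown, and "the series" means these compounds.

Four compounds built around a shared quinazolinone-bearing fragment are compared here, each measured or to be measured in a functional assay on the whole organism (strain albino) for inhibition, with Rattus norvegicus as the target, read by paw edema, with stated times of 1 h and 2 h, at a dose of 100 mg/kg by the oral route; a higher number here means more inhibition at the dose given (going by the name of the read-out), a lower number less inhibition. Compound 1, with structure `O=C(CSc1nc(-c2ccccc2)c(C(=O)O)c(=O)[nH]1)Nn1c(COc2ccc(Cl)cc2Cl)nc2ccccc2c1=O`, gives 68.4% in this assay. Compound 2, `O=C(CSc1nc(-c2ccc(Cl)cc2)c(C(=O)O)c(=O)[nH]1)Nn1c(COc2ccc(Cl)cc2Cl)nc2ccccc2c1=O`, carries the change chloro in place of hydrogen on an aromatic carbon and gives 61.4%. The step of a number 7 percentage points lower from compound 1 to compound 2 (within the scatter) is small and sits inside the usual run-to-run scatter, so the two values cannot be told apart with confidence.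

Compound 3, `N#Cc1c(Cl)nc(SCC(=O)Nn2c(COc3ccc(Cl)cc3Cl)nc3ccccc3c2=O)nc1-c1ccccc1`, rests on a different core; the difference between the two cores is not broken down here. In this assay compound 3 gives 66.7%, a number close to that of compound 1 and also within the scatter of compound 2, so no order among the three can be drawn.

Compound 4, `N#Cc1c(Cl)nc(SCC(=O)Nn2c(COc3ccc(Cl)cc3Cl)nc3ccccc3c2=O)nc1-c1ccc(Cl)cc1`, has not yet been measured. Relative to compound 3 it carries chloro in place of hydrogen on an aromatic carbon, placed on an aromatic carbon of a six-membered aromatic ring of carbon only, para to a large group, exactly as in the change from compound 1 to compound 2. Since the same change made only the small step of a number 7 percentage points lower from compound 1 to compound 2 (within the scatter) on the first core, a similarly small step is expected on the second core: the estimated step is a number 6.7 percentage points lower from compound 3 to compound 4 (within the scatter), resting on that single precedent. Compound 4 is therefore expected to give about 60%, with a plausible range from 49% to 71%.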

Compound 4, a percentage reported as inhibition, in the whole organism at one dose (the size of the read-out at that dose, not a potency): 68.4%
Compound 4: middle estimate off by 8.4 percentage points, on the low side; low and high end bracket the measured number.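

In this assay, the change from phenyl to 4-chlorophenyl on the second core gives a number 1.7 percentage points higher from compound 3 to compound 4 (within the scatter). Set beside the same change on the first core, this step cannot be told apart from the earlier one: the same change on two cores in this assay, a number 7 percentage points lower (within the scatter) from compound 1 to compound 2 and a number 1.7 percentage points higher (within the scatter) from compound 3 to compound 4, 8.7 percentage points apart, within the scatter of two such steps On both cores the swap stays within the usual scatter of the measurement, so the two cores agree in the limited sense that neither shows a clear effect of the added chloro, but this does not prove that the chloro does nothing or that its effect is identical on the two cores, since there are only two such pairs, each read at a single oral dose, and a read-out at one dose is not a potency.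

The compounds shown hold only hydrogen or chloro at this place on the phenyl ring, so it remains open how a methoxy group or an amine there would behave on either core. The other ring bearing two chlorines is the same in all four compounds, which leaves open what would follow if a methyl group took the place of either chlorine.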